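From 2-chlorophenyl to 4-chlorophenyl: an expected limit

The source may report more compounds than this note shows. Statements on the series, on what has been measured and on what is new or still open speak of the compounds shown alone.

Three measured compounds share one core and differ only in the aryl group on the double-bonded chain carbon. Compound 1 `O=C(/C=C\c1ccc([N+](=O)[O-])cc1)N1N=C(c2ccncc2)OC1c1c[nH]c2ccccc12` carries a 4-nitrophenyl group. In an ADME assay on HeLa cells (Homo sapiens) for cytotoxicity, read by MTT assay, with a stated time of 72 h (on this read-out lower numbers stand for stronger inhibition of growth and higher numbers for weaker inhibition of growth), compound 1 gives only a limit of the assay, > 30 ug/mL. Compound 2 `COc1ccc(/C=C\C(=O)N2N=C(c3ccncc3)OC2c2c[nH]c3ccccc23)cc1` carries a 4-methoxyphenyl group, and in this assay compound 2 likewise gives only a limit, > 30 ug/mL. Compound 3 `O=C(/C=C\c1ccccc1Cl)N1N=C(c2ccncc2)OC1c1c[nH]c2ccccc12` carries a 2-chlorophenyl group; in this assay compound 3 also gives only a limit, > 30 ug/mL. Because of the limit of > 30 ug/mL in this assay, at which 3 of the 3 values shown sit, none of the steps between them can be read: a step that the two limits leave unreadable from compound 1 to compound 2, a step that the two limits leave unreadable from compound 1 to compound 3 and a step that the two limits leave unreadable from compound 2 to compound 3 all remain unreadable in size.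

Compound 4 `O=C(/C=C\c1ccc(Cl)cc1)N1N=C(c2ccncc2)OC1c1c[nH]c2ccccc12` is the next case. It differs from compound 3 by 4-chlorophenyl in place of 2-chlorophenyl on a double-bonded chain carbon bound to a double-bonded chain carbon. Going by the values given here, the three measured steps bear on this change only in that no aryl variation so far has brought a readable number; none of them gives a size. So in this assay no step beyond the scatter is expected, and the estimated step of a number no higher from compound 3 to compound 4 (the limit leaves the size open) means compound 4 is expected to sit at a limit as well. The estimate for compound 4 is 30 ug/mL, between 15 ug/mL and 60 ug/mL.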

Compound 4, concentration for 50% growth inhibition: > 30 ug/mL
Compound 4 was reported as a limit; the forecaster's own chance of this, stated with the estimate: 85%; the middle value sits exactly at the limit.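

No step from compound 1, compound 2 or compound 3 to compound 4 can be read, and the cause is a single one: the limit of > 30 ug/mL in this assay, at which 4 of the 4 values shown sit. The compounds shown leave open what size any change of the aryl group has in this assay, since none of them yet gives a number rather than a limit.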